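The source may hold more compounds than are shown below. What is called first, only, known or untested is meant among the compounds shown, and "the series" means these compounds.

Working notes on the series, read in an ADME assay on a cell-free system (serum, Homo sapiens) for metabolic stability, read by HPLC, tested at 2 mM; on this read-out higher numbers stand for a longer-lived compound and lower numbers for a shorter-lived compound. Compound 1 `CCCCCCCCCc1ccc(OP(=O)(O)OC[C@H]2O[C@@H](n3cc(F)c(=O)[nH]c3=O)C[C@@H]2OC(=O)c2ccccc2)cc1` gives > 120 h, which is a limit of the assay and not a number. Compound 2 `O=C(O[C@H]1C[C@H](n2cc(F)c(=O)[nH]c2=O)O[C@@H]1COP(=O)(O)Oc1ccc2ncccc2c1)c1ccccc1` gives 16.5 h and compound 3 `CCCCCCCCCC[n+]1cccc(OP(=O)([O-])OC[C@H]2O[C@@H](n3cc(F)c(=O)[nH]c3=O)C[C@@H]2OC(=O)c2ccccc2)c1` gives 8.3 h, and these two values lie within the usual scatter of each other. Among the compounds with values here, compound 3 therefore stands level with compound 2, the only other measured number.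

Compound 4 `CCOC(=O)C[n+]1cccc(OP(=O)([O-])OC[C@H]2O[C@@H](n3cc(F)c(=O)[nH]c3=O)C[C@@H]2OC(=O)c2ccccc2)c1` differs from compound 3 in one place: ethoxycarbonyl in place of nonyl on a saturated chain carbon bound to an aromatic nitrogen. This puts ethoxycarbonyl in place of nonyl on a saturated chain carbon bound to an aromatic nitrogen. Within the data shown here, no measured step covers this change, so the expectation starts from compound 3 at 8.3 h and carries wide uncertainty. The step expected in this assay is a 2.4-fold lower number from compound 3 to compound 4 (0.38 log units; beyond the scatter), towards a shorter-lived compound, though a result inside the scatter would not be surprising. For compound 4 the estimated half-life is 3.5 h, with an expected range of 0.8 h to 12 h.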

Compound 4, half-life in the Homo sapiens assay: 1.4 h
Compound 4: middle estimate off by 2.5-fold (0.40 log units), on the high side; the measured number falls inside the stated range.
By their numbers in the Homo sapiens assay, from the lowest: compound 4; then compounds 3 and 2 (each within the scatter of the next). At a limit, above all of these: compound 1.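

Within the data shown here, the chain on this aromatic nitrogen had not been varied among the earlier compounds, and the half-life proves responsive to it. In the Homo sapiens assay compound 3 gives 8.3 h and compound 4 gives 1.4 h. With ethoxycarbonyl in place of nonyl, the Homo sapiens assay shows a 5.9-fold lower number from compound 3 to compound 4 (0.77 log units; beyond the scatter). In a physicochemical assay for metabolic stability, read by HPLC, tested at 2 mM (a higher number here means that the compound lasts longer, a lower number that the compound disappears faster), compound 3 gives 16.5 h and compound 4 gives 1.1 h. The same change in the physicochemical assay gives a 15-fold lower number from compound 3 to compound 4 (1.18 log units; beyond the scatter), so both read-outs move in the same direction, towards a shorter-lived compound. This direction rests on a single pair and holds for these two compounds alone.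

Going by these compounds, whether the shift follows the loss of the nonyl chain or the arrival of the ethoxycarbonyl group stays open; a butyl chain, or a carboxylic acid on the same saturated chain carbon, would separate the two. In the Homo sapiens assay compound 1 gives > 120 h, which is a limit of the assay and not a number.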